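The source may hold more compounds than are shown below. What is called first, only, known or untested is meant among the compounds shown, and "the series" means these compounds.

Compound 1 `CS(=O)(=O)C1CCN(C(=O)CCSc2nc3cc(Cl)ccc3o2)C1`, compound 2 `CN(CCC(=O)N1CCCC1)c1nc2cc(Cl)ccc2o1`, compound 3 `CCN(CC)C(=O)CCSc1nc2cc(Cl)ccc2o1` and the not yet measured compound 4 `O=C(CCNc1nc2cc(Cl)ccc2o1)N1CCCC1` share one core. In an ADME assay on microsomes from liver (Homo sapiens) for metabolic stability, read by LC-MS, using NADPH, with a stated time of 45 min, tested at 0.5 uM (on this read-out higher numbers stand for fast clearance and lower numbers for slow clearance), compound 1 gives only a limit, < 0.4 mL/min/g. In this assay compound 2 gives 1.9 mL/min/g, the lower of the two numbers read in the series. Compound 3 gives 5.9 mL/min/g, a gap to compound 2 that is beyond the scatter. Of the three readings, one is the limit of < 0.4 mL/min/g in this assay, at which 1 of the 3 values shown sits. Compound 4 differs from compound 2 by hydrogen in place of methyl on a nitrogen on an aromatic ring. Going by the values given here, no measured pair carries this change, so its size is unknown; a modest fall in clearance, or none beyond the scatter, is expected. Compound 4 is estimated at 1.2 mL/min/g, with a range from 0.5 mL/min/g to 3 mL/min/g. That estimate is expected to mean a step of a 1.6-fold lower number from compound 2 to compound 4 (0.20 log units; within the scatter).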

Compound 4, intrinsic clearance in a liver preparation (reported as CLH), per the amount of preparation that the assay uses: 2.3 mL/min/g
Estimate against measurement, compound 4: 1.9-fold (0.28 log units) below; the range from low to high includes it.
By their numbers in this assay, from the lowest: compounds 2 and 4 (each within the scatter of the next); then compound 3. At a limit, below all of these: compound 1.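

Going by these compounds alone, the first pair that differs in one place gives, in this assay, a 1.2-fold higher number from compound 2 to compound 4 (0.08 log units; within the scatter) for hydrogen in place of methyl on a nitrogen on an aromatic ring. In this pair, the methyl at this position can therefore be lost with no shift in clearance beyond the scatter. No measurement at hand accounts for this result.

From the compounds shown here alone, how an ethyl group or a longer chain on this nitrogen would read remains open. So does whether the same swap gives the same result with the diethyl amide of compound 3 in place of the amide of compound 2.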